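Switching the Drawn Configuration of a Urea

The source may hold more compounds than are shown below. What is called first, only, known or untested is meant among the compounds shown, and "the series" means these compounds.

In an ADME assay on the whole organism with Oryza sativa as the target, tested at 0.1 uM (on this read-out higher numbers stand for a weaker effect at the one concentration tested and lower numbers for a stronger effect), compound 1 `C[C@H](NC(=O)Nc1cccc(C(F)(F)F)c1)c1ccccc1` gives 94%. Compound 2 `C[C@H](NC(=O)Nc1cc(F)ccc1F)c1ccccc1` gives 100% in this assay. Compound 3 `C[C@@H](NC(=O)Nc1cc(C(F)(F)F)ccc1F)c1ccccc1` gives 87%, the lowest of the three numbers: the gap to compound 1 lies within the usual scatter, while the gap to compound 2 lies beyond it. Compound 4 `C[C@H](NC(=O)Nc1cc(C(F)(F)F)ccc1F)c1ccccc1` has not yet been measured. How compound 4 differs from compound 3: the two compounds have the same atoms and bonds and differ only in configuration as drawn: 1 of 1 stereo elements differ; a stereocentre at a saturated chain carbon is drawn R in compound 3 and S in compound 4. Going by the values given here, no measured pair of compounds shows this kind of change, so there is no step to lean on. A small rise is expected for compound 4, though it may not reach beyond the scatter, because compound 1 sits at 94% and compound 2 sits at 100% in this assay, both drawn with the other configuration. For compound 4 the estimate is 95%, with a range from 84% to 100%, an expected step of a number 8 percentage points higher from compound 3 to compound 4 (within the scatter).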

Compound 4, a percentage reported as activity, at one concentration (the size of the read-out at that concentration, not a potency): 98%
The estimate for compound 4 lay 3 percentage points below the measured number, within the range that was stated.
By their numbers in this assay, from the lowest: compounds 3, 1, 4 and 2 (each within the scatter of the next, the first and the last beyond it).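

In this assay, the drawn configuration of the stereocentre at a saturated chain carbon proves able to shift the read-out on its own, giving a number 11 percentage points higher from compound 3 to compound 4 (beyond the scatter). That shift can be assigned to the stereocentre because nothing else separates the pair: the fact that compounds 3 and 4 differ only in the configuration as drawn

With the configuration drawn as S, the ring changes stay small by comparison: trifluoromethyl in place of fluoro gives a number 2 percentage points lower from compound 2 to compound 4 (within the scatter), and fluoro in place of hydrogen gives a number 4 percentage points higher from compound 1 to compound 4 (within the scatter).

On these data alone, whether switching the configuration would act the same way on the cores of compound 1 and compound 2 stays open. So does the effect of a longer chain at the stereocentre, or of a methoxy group on the aromatic ring.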